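The compounds below may be only part of what the source reports. "The series", "measured", "known", "first", "only" and "open" are said of these compounds alone.

Of the compounds shown here, three sharing one core have been tested in an assay for binding affinity to Apoptosis regulator Bcl-2 (Homo sapiens), read by fluorescence polarization, with stated times of 30 min and 20 min, tested at 100 uM; on this read-out lower numbers stand for less inhibition and higher numbers for more inhibition at the one concentration tested (going by the name of the read-out). Compound 1 `COc1ccc(Oc2ccccc2-c2ccsc2S(=O)(=O)N2CCN(C(=S)Nc3ccc([N+](=O)[O-])cc3)CC2)cc1OC` gives 16% in this assay. Among the compounds with values here, compound 2 `COc1ccc(Oc2ccc([N+](=O)[O-])cc2-c2ccsc2S(=O)(=O)N2CCN(C(=S)Nc3ccc([N+](=O)[O-])cc3)CC2)cc1OC` gives 16% in this assay; it carries a nitro in place of hydrogen on an aromatic carbon, and the step of no change at the digits printed from compound 1 to compound 2 (within the scatter) is the only single-point change measured so far. Compound 3 `COc1ccc(Oc2ccccc2-c2ccsc2S(=O)(=O)N2CCN(C(=S)Nc3cc(C(F)(F)F)cc(C(F)(F)F)c3)CC2)cc1OC` gives 25% in this assay; this is the highest of the three numbers shown, yet its gap to compound 1 and its gap to compound 2 both lie within the scatter, so no real ranking of the three can be drawn.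

Compound 4 `O=S(=O)(c1sccc1-c1ccccc1Oc1ccc(O)c(O)c1)N1CCN(C(=S)Nc2cc(C(F)(F)F)cc(C(F)(F)F)c2)CC1` has not yet been measured. It differs from compound 3 in one place: 3,4-dihydroxyphenyl in place of 3,4-dimethoxyphenyl on an oxygen on an aromatic ring. Two hydrogen-bond donors enter with this change and two carbon atoms leave. Within the data shown here, no measured step touches this part of the molecule; the one step available, no change at the digits printed from compound 1 to compound 2 (within the scatter), concerns a nitro group on a different ring and showed nothing beyond the scatter, so it offers no guide to size or direction here. With nothing pointing either way, the step is expected to be no change at the digits printed from compound 3 to compound 4 (within the scatter), no change beyond the scatter. Compound 4 is therefore estimated to give 25% in this assay, within a range from 10% to 40%.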

Compound 4, a percentage reported as inhibition, at one concentration (the size of the read-out at that concentration, not a potency): 20%
For compound 4 the middle estimate is 5 percentage points above the measured one; the range from low to high includes it.
By their numbers in this assay, from the lowest: compounds 1, 2, 4 and 3 (each within the scatter of the next).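

In this assay, placing 3,4-dihydroxyphenyl where 3,4-dimethoxyphenyl stood, on an oxygen on an aromatic ring, gives a number 5 percentage points lower from compound 3 to compound 4 (within the scatter). Within the data shown here, this is the first measured look at this end of the molecule, since the only earlier step concerned a nitro group elsewhere, and it shows that hydrogen-bond donors can enter here and the methyl carbons can leave without the read-out separating the two compounds, with compound 4 at 20%. The result is a reading at one concentration rather than a potency, and no other measurement is at hand to say what lies behind it.

On these data alone, whether this position can respond at all stays open, as a 3,4-dimethoxyphenyl and a 3,4-dihydroxyphenyl are close relatives, and a phenyl ring carrying a carboxylic acid or an amine, or longer chains such as ethoxy groups, might give a number beyond the scatter. Also open, as far as these compounds go, is whether the same exchange would read the same way on a compound with another thiourea aryl group, such as the 4-nitrophenyl of compound 1.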